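Pyrazole carboxamides at the EP1 receptor: pyridyl isomer

This account rests on a few compounds, and the source may have more. Where it says the series, first, only, none or still open, it means among the compounds named here.

Measured so far:
compound 1 `Cc1cc(C(N)=O)nn1Cc1cc(Cl)ccc1OCc1ccccc1`: 126 nM
compound 2 `Cc1cc(C(=O)NCc2ccccn2)nn1Cc1cc(Cl)ccc1OCc1ccccc1`: 25.1 nM

Both values come from an assay on CHO-K1 cells for displacement of a labelled ligand from prostaglandin E2 receptor EP1 subtype (Homo sapiens); on this read-out lower numbers stand for stronger inhibition and higher numbers for weaker inhibition. Going by the values given here, compound 2 has the lower of the two numbers, the only step being a 5.0-fold lower number from compound 1 to compound 2 (0.70 log units; beyond the scatter), a modest gain from putting (pyridin-2-yl)methyl on the amide-type nitrogen.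

Compound 3 `Cc1cc(C(=O)NCc2ccncc2)nn1Cc1cc(Cl)ccc1OCc1ccccc1` keeps the same atoms and changes only the ring attachment: pyridin-4-yl in place of pyridin-2-yl on a saturated chain carbon bound to an amide-type nitrogen. Among the compounds with values here, no measured pair speaks to moving the nitrogen within the pyridine ring; the step from compound 1 to compound 2 shows only that the pyridylmethyl substituent as a whole helps, not which isomer is preferred. The expectation in this assay is therefore no change beyond the scatter, with the range widened to allow for a loss or a further gain.

Compound 3 is estimated at 40 nM, between 12 nM and 130 nM, i.e. a 1.6-fold higher number from compound 2 to compound 3 (0.20 log units; within the scatter).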

Compound 3, half-maximal inhibitory concentration: 79.4 nM
The estimate for compound 3 lay 2.0-fold (0.30 log units) below the measured number; low and high end bracket the measured number.
By their numbers in this assay, from the lowest: compound 2; then compounds 3 and 1 (each within the scatter of the next).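

The placement of the ring nitrogen matters in this assay: pyridin-4-yl in place of pyridin-2-yl on the saturated chain carbon gives a 3.2-fold higher number from compound 2 to compound 3 (0.50 log units; beyond the scatter) and thus gives up most of the earlier gain. Set against the plain amide, (pyridin-4-yl)methyl on the amide-type nitrogen gives a 1.6-fold lower number from compound 1 to compound 3 (0.20 log units; within the scatter) and so shows no gain beyond the scatter, which ties the improvement seen so far to the (pyridin-2-yl)methyl group of compound 2 and not to pyridylmethyl substituents in general. Nothing available explains the gap between the two isomers.

Open, on these data alone, is whether pyridin-3-yl on the same carbon would read with compound 2 or with compound 3. Also open, as far as these compounds go, is whether a plain phenyl there, or a longer 2-(pyridin-2-yl)ethyl group on the amide-type nitrogen, would hold the value of compound 2.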